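Expected Inhibition for Compound 3 After a Ring-for-Chain Exchange

This account rests on a few compounds, and the source may have more. Where it says the series, first, only, none or still open, it means among the compounds named here.

Of the compounds shown here, two built on the same core have been tested in a functional assay on the whole organism (strain albino) for inhibition, with Rattus norvegicus as the target, read by paw edema, with stated times of 1 h and 2 h, at a dose of 20 mmol/kg by the intraperitoneal route; a higher number here means more inhibition at the dose given (going by the name of the read-out), a lower number less inhibition. Compound 1 `N#CC1=C(NCN2CCCC2)N(c2ccccc2)C(=O)N2CCCCC(N3CCCC3)C12` gives 26.6%. Compound 2 `N#CC1=C(/N=C/c2ccccc2)N(c2ccccc2)C(=O)N2CCCCC(N3CCCC3)C12` gives 75.9%, the highest of the two numbers; its nearest neighbour is compound 1, and the step of a number 49.3 percentage points higher from compound 1 to compound 2 (beyond the scatter) lies beyond the scatter.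

Compound 3 `CCOC(=O)C(=O)NC1=C(C#N)C2C(N3CCCC3)CCCCN2C(=O)N1c1ccccc1` has not yet been measured. It differs from compound 2 in one place: a group of 8 heavy atoms (4 carbon, 1 nitrogen, 3 oxygen; no ring) in place of a group of 8 heavy atoms (7 carbon, 1 nitrogen; one six-membered aromatic ring of carbon only), on a double-bonded ring carbon.

Among the compounds with values here, only one measured step touches this position, and it bears on the new change only loosely. Going from a group of 7 heavy atoms with a five-membered non-aromatic ring to a group of 8 heavy atoms with a six-membered aromatic ring raised inhibition by a number 49.3 percentage points higher from compound 1 to compound 2 (beyond the scatter). Within the data shown here, in compound 3 the aromatic ring leaves again, and the entering ((ethoxycarbonyl)carbonyl)amino group, with no ring and one hydrogen-bond donor, has no measured counterpart. The analysis therefore expects a drop from compound 2, but with wide uncertainty. The expected step is a number 30.9 percentage points lower from compound 2 to compound 3 (beyond the scatter). The estimate for compound 3 is 45%, within a range from 20% to 72%.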

Compound 3, a percentage reported as inhibition, in the whole organism at one dose (the size of the read-out at that dose, not a potency): 83.6%
For compound 3 the middle estimate is 38.6 percentage points below the measured one; the whole stated range lies below it.
By their numbers in this assay, from the lowest: compound 1; then compounds 2 and 3 (each within the scatter of the next).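

In this assay the exchange on the double-bonded ring carbon gives a number 7.7 percentage points higher from compound 2 to compound 3 (within the scatter) and so shows that a six-membered aromatic ring of carbon only is not required at this position for a high number at the dose given. The step of a number 57 percentage points higher from compound 1 to compound 3 (beyond the scatter) comes with (ethoxycarbonyl)carbonyl in place of (pyrrolidin-1-yl)methyl on an amine nitrogen, so the low number of compound 1 cannot be put down simply to the lack of an aromatic ring in this group, as compound 3 has none there either. What makes the ((ethoxycarbonyl)carbonyl)amino group compatible with this level of inhibition remains unexplained, as no measurement of any property of these groups is available.

On these data alone, it remains open whether a carboxylic acid or a plain acetyl group in place of the ethoxycarbonyl part would give a number close to that of compound 3. As far as these compounds go, the comparison also rests on a single dose, so how compound 2 and compound 3 stand relative to each other at other doses is unknown.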